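The compounds below may be only part of what the source reports. "The series", "measured", "known", "first", "only" and "open" are said of these compounds alone.

Compound 1 `COc1cc(OC)c(OC)cc1/C=C/COC(=O)/C=C/c1cc(OC)c(OC)c(OC)c1OC` gives 50% in a functional assay on the whole organism (strain Kunming) with Mus musculus as the target, with a stated time of 0.5 h, at a dose of 300 mg/kg by the intraperitoneal route; a lower number here means a stronger effect, a higher number a weaker effect of the compound at the dose given. Among the measured compounds shown here, compound 3 `COc1cc(OC)c(OC)cc1/C=C/COC(=O)/C=C/c1cc(OC)c(OC)c(OC)c1` gives 75% in this assay, and the single change from compound 1 to compound 3, hydrogen in place of methoxy on an aromatic carbon, is measured as a number 25 percentage points higher from compound 1 to compound 3 (beyond the scatter). Compound 2 `COc1cc(OC)c(OC)cc1/C=C/COC(=O)/C=C/c1ccccc1C(F)(F)F` gives 75% in this assay, level with compound 3 at the digits shown; the two values are within the scatter of each other and together they are the highest of the three numbers, while compound 1 stands lower by a gap beyond the scatter.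

Compound 4 `COc1cccc(/C=C/C(=O)OC/C=C/c2cc(OC)c(OC)cc2OC)c1` has not yet been measured. It differs from compound 2 in one place: 3-methoxyphenyl in place of 2-(trifluoromethyl)phenyl on a double-bonded chain carbon bound to a double-bonded chain carbon. For the measured compounds named here, no measured step exchanges one aryl group for another; the only measured step, from compound 1 to compound 3, removes a single methoxy and is of modest size. The two measured aryl groups on that chain carbon, in compound 2 and compound 3, give values within the scatter of each other, so a third aryl group is expected to land near them. The step from compound 2 to compound 4 is therefore expected to be a number 5 percentage points lower from compound 2 to compound 4 (within the scatter), nothing beyond the scatter. Compound 4 is estimated to give 70% in this assay, within a range from 50% to 90%.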

Compound 4, a percentage reported as activity, at one dose (the size of the read-out at that dose, not a potency): 75%
The estimate for compound 4 lay 5 percentage points below the measured number; low and high end bracket the measured number.
By their numbers in this assay, from the lowest: compound 1; then compounds 2, 3 and 4 (each within the scatter of the next).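

In this assay, the exchange of 2-(trifluoromethyl)phenyl for 3-methoxyphenyl on a double-bonded chain carbon bound to a double-bonded chain carbon gives no change at the digits printed from compound 2 to compound 4 (within the scatter) in a direct comparison. Among the compounds shown here, this is the first measured step that swaps one whole aryl group for another at this place, and the read-out stays level even though three fluorine atoms leave and an oxygen with one hydrogen-bond acceptor enters. Nothing measured here explains why these two groups read alike.

Going by these compounds, it remains open whether an amine or a carboxylic acid on this aryl group would also leave the read-out unchanged, or whether only further methoxy groups move it. Also open, on these data alone, is whether a longer chain in place of the double-bonded chain would hold the read-out at this level.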